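This account rests on a few compounds, and the source may have more. Where it says the series, first, only, none or still open, it means among the compounds named here.

In a functional assay on MCF7 cells (Homo sapiens) for cytotoxicity, read by MTT assay, with a stated time of 4 h (on this read-out higher numbers stand for weaker inhibition and lower numbers for stronger inhibition), compound 1 `O=C1N=C(NN2Cc3ccccc3N=C2c2ccccc2)S/C1=C/c1ccc(Br)cc1` gives 2300 nM, and compound 2 `O=C1N=C(NN2Cc3ccccc3N=C2c2ccccc2)S/C1=C/c1ccccc1` gives 4050 nM. The two differ by hydrogen in place of bromo on an aromatic carbon, and the step of a 1.8-fold higher number from compound 1 to compound 2 (0.25 log units; within the scatter) shows how little that change did here. Compound 3 `O=C(CNc1ccc(Br)cc1)Nn1c(-c2ccccc2)nc2ccccc2c1=O` rests on a different core; the difference between the two cores is not broken down here. In this assay compound 3 gives 15100 nM, the highest of the three numbers, beyond the scatter from both compound 1 and compound 2.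

Compound 4 `O=C(CNc1ccccc1)Nn1c(-c2ccccc2)nc2ccccc2c1=O` has not yet been measured. It stands to compound 3 as compound 2 stands to compound 1, by hydrogen in place of bromo on an aromatic carbon, the same change at the same kind of place. Among the compounds with values here, with only one earlier example of this change, the expectation is that compound 4 will sit close to compound 3 or somewhat higher. The expected step is a 1.7-fold higher number from compound 3 to compound 4 (0.22 log units; within the scatter), a size chosen because a 1.8-fold higher number from compound 1 to compound 2 (0.25 log units; within the scatter) is the only reference this set offers. Compound 4 is therefore estimated in this assay at 25000 nM, with a likely range from 12000 nM to 55000 nM.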

Compound 4, half-maximal inhibitory concentration: 15300 nM
Estimate against measurement, compound 4: 1.6-fold (0.21 log units) above, and the stated range covers the measured number.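

In this assay, exchanging the 4-bromophenyl for phenyl on the core of compound 3 gives a 1.0-fold higher number from compound 3 to compound 4 (0.01 log units; within the scatter), so this step, like the earlier one, cannot be told from the scatter. Set side by side, the two steps do not differ in any readable way: the same change on two cores in this assay, a 1.8-fold higher number (0.25 log units; within the scatter) from compound 1 to compound 2 and a 1.0-fold higher number (0.01 log units; within the scatter) from compound 3 to compound 4, 1.7-fold (0.24 log units) apart, within the scatter of two such steps

This shows that, across these two pairs, replacing bromo with hydrogen gave no readable shift on either core, so the result carried over from one core to the other. It does not show that the same would hold on any further core or at any other place on the ring, and two steps that both lie within the scatter cannot establish a general rule for the series.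

The compounds shown leave open whether a chloro, methoxy or nitro group on that same aromatic carbon would move the number beyond the scatter on either core. They also leave open what a longer chain in place of the anilinomethyl group would do on the core of compound 3.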